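The compounds below may be only part of what the source reports. "The series", "measured", "known", "first", "only" and "open" are said of these compounds alone.

Compound 1 `CCC(C(=O)N1CCN(c2ccccc2F)CC1)N1C(=O)CCC1=O` and compound 2 `CCC(C(=O)N1CCN(c2ccc(C(F)(F)F)cc2)CC1)N1C(=O)CCC1=O` share the same core and differ only in the group carried on the six-membered aromatic ring of carbon only. In a functional assay on the whole organism (strain Swiss) with Mus musculus as the target, in the maximal electroshock model, with a stated time of 2 h, at a dose of 300 mg/kg by the intraperitoneal route (on this read-out lower numbers stand for a weaker effect and higher numbers for a stronger effect at the one dose given), compound 1 gives 0%. In this assay compound 2 gives 0%, level with compound 1 at the digits shown, a gap that lies within the usual scatter of this kind of measurement. Neither compound therefore shows any measurable protection at the single dose used.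

Compound 3 `CCC(C(=O)N1CCN(c2ccccc2)CC1)N1C(=O)CCC1=O` is the next member of the series, and it differs from compound 2 in one place: hydrogen in place of trifluoromethyl on an aromatic carbon. Going by the values given here, no step between two measured compounds has been seen here, so there is nothing in the numbers that points either up or down. Because compound 2 gives 0% in this assay, the step from trifluoromethyl to hydrogen is expected to be no change at the digits printed from compound 2 to compound 3 (within the scatter), that is, no change beyond the scatter. Compound 3 is accordingly estimated to give 0% in this assay, with an expected range from 0% to 15%.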

Compound 3, a percentage reported as activity, at one dose (the size of the read-out at that dose, not a potency): 25%
Beside the measured number, compound 3's estimate is 25 percentage points below it; measured number above the stated range.
By their numbers in this assay, from the lowest: compounds 1 and 2 (each within the scatter of the next); then compound 3.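

The two earlier compounds could not show whether the aromatic ring matters in this series, since both sat level at the bottom of the read-out. Going by these compounds alone, compound 3 shows that it does: in this assay, hydrogen in place of trifluoromethyl gives a number 25 percentage points higher from compound 2 to compound 3 (beyond the scatter), and hydrogen in place of fluoro gives a number 25 percentage points higher from compound 1 to compound 3 (beyond the scatter), so of these three compounds only the one with no group on the ring shows any protection at the single dose used. Nothing available explains why these changes raise the read-out, and one dose gives the size of the effect at that dose, not a potency.

The compounds shown leave open whether the drop in protection belongs to fluorine-bearing groups in particular or would follow any group on the ring, and a methyl group, a methoxy group or a chlorine atom on the same aromatic carbon would help separate the two. Compounds 1 and 2 both read at the bottom of the scale, so they also leave open how these two groups would rank against each other.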